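Paw edema series: isopropyl counterparts of two tert-butyl esters

The source may report more compounds than this note shows. Statements on the series, on what has been measured and on what is new or still open speak of the compounds shown alone.

Compound 1 `Cc1ccc(-c2cc(C(=O)Oc3ccc(C(C)(C)C)cc3)n(Cc3ccccc3)n2)cc1` and compound 3 `Cc1ccc(-c2cc(C(=O)Oc3ccc(C(C)(C)C)cc3)nn2Cc2ccccc2)cc1` are built from the same atoms joined differently; the difference between the two cores is not broken down here. In a functional assay on the whole organism (strain Swiss albino) for inhibition, with Mus musculus as the target, read by paw edema, with stated times of 30 min and 270 min, at a dose of 100 mg/kg by the subcutaneous route (on this read-out lower numbers stand for less inhibition and higher numbers for more inhibition at the one dose given (going by the name of the read-out)), compound 1 gives 50%, and compound 3 gives 54%, the two numbers lying within the usual scatter of each other. Compound 2 `Cc1ccc(-c2cc(C(=O)Oc3ccc(C(C)C)cc3)n(Cc3ccccc3)n2)cc1` differs from compound 1 by hydrogen in place of methyl on a saturated chain carbon bound to an aromatic carbon and two saturated chain carbons, and in this assay compound 2 gives 29%; the step is a number 21 percentage points lower from compound 1 to compound 2 (beyond the scatter). Compound 4 `Cc1ccc(-c2cc(C(=O)Oc3ccc(C(C)C)cc3)nn2Cc2ccccc2)cc1` stands to compound 3 as compound 2 stands to compound 1, the change being (hydrogen in place of methyl on a saturated chain carbon bound to an aromatic carbon and two saturated chain carbons), the same change made on the core of compound 3 instead. Its number in this assay is not yet known. Going by the values given here, because a number 21 percentage points lower from compound 1 to compound 2 (beyond the scatter) is the only earlier instance of this change, a step of similar size is expected, a number 21 percentage points lower from compound 3 to compound 4 (beyond the scatter). Among the compounds with values here, compound 4 is therefore estimated at 33%, with a range from 18% to 48% that allows for the scatter of a single measurement and for the single precedent.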

Compound 4, a percentage reported as inhibition, in the whole organism at one dose (the size of the read-out at that dose, not a potency): 50.4%
Estimate against measurement, compound 4: 17.4 percentage points below; the measured number lies above the stated range.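

Working notes: in this assay, the change from tert-butyl to isopropyl does not carry from one core to the other at the same size: the same change on two cores in this assay, a number 21 percentage points lower (beyond the scatter) from compound 1 to compound 2 and a number 3.6 percentage points lower (within the scatter) from compound 3 to compound 4, 17.4 percentage points apart, beyond the scatter of two such steps

On the core of compound 3, the change gives a number 3.6 percentage points lower from compound 3 to compound 4 (within the scatter) so the clear step seen on the core of compound 1 does not predict the step on this core. This shows that the step depends on the core in these two matched pairs, but with one pair per core it does not show why the steps differ or how the change would behave on any further core.

The compounds shown leave open whether the dependence on the core is specific to isopropyl or would also appear with an ethyl group, a methoxy group or a carboxylic acid in place of tert-butyl. They also leave open whether the same picture would hold at other doses, since each number comes from a single dose.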